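This account rests on a few compounds, and the source may have more. Where it says the series, first, only, none or still open, it means among the compounds named here.

The series shares the core seen in compound 1 `CC(C)NC(=O)c1ccc(NCc2cncn2Cc2ccc(C#N)cc2)cc1-c1ccccc1`, where an isopropyl group sits on the amide-type nitrogen. In a functional assay on NIH3T3 cells (Mus musculus) (on this read-out higher numbers stand for an effect only at larger amounts of compound and lower numbers for an effect already at smaller amounts), compound 1 gives > 10 uM, which is a limit of the assay rather than a number. Compound 2 `N#Cc1ccc(Cn2cncc2CNc2ccc(C(=O)NCc3ccccc3)c(-c3ccccc3)c2)cc1` carries a benzyl group in the same place. In this assay compound 2 gives > 10 uM, again a limit. Compound 3 `CSCC[C@H](NC(=O)c1ccc(NCc2cncn2Cc2ccc(C#N)cc2)cc1-c1ccccc1)C(=O)O` carries the 1-carboxy-3-(methylsulfanyl)propyl group there. In this assay compound 3 gives > 10 uM, also a limit, so compound 3 stands at the same limit as the other two and no order among the three can be read. Accordingly the steps a step that the two limits leave unreadable from compound 1 to compound 2, a step that the two limits leave unreadable from compound 1 to compound 3 and a step that the two limits leave unreadable from compound 2 to compound 3 all remain unreadable because of the limit of > 10 uM in this assay, at which 3 of the 3 values shown sit.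

Compound 4 `N#Cc1ccc(Cn2cncc2CNc2ccc(C(=O)NCC3CCCCC3)c(-c3ccccc3)c2)cc1` differs from compound 3 by cyclohexylmethyl in place of 1-carboxy-3-(methylsulfanyl)propyl on an amide-type nitrogen. All three measured steps alter the group on the amide-type nitrogen, and none of them left the limit, so they bear on this change only by showing that three different groups there produced no readable effect. The step in this assay is therefore expected to be a step that the limit leaves unreadable from compound 3 to compound 4, with a good chance that only a limit is reported again. Compound 4 is estimated at 20 uM, in a range from 5 uM to 80 uM.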

Compound 4, concentration for half-maximal effect: > 10 uM
Compound 4 gave a limit, no number (the forecaster's own chance of this, stated with the estimate: 70%); the middle value is on the limit's open side.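

In this assay compound 4 gives > 10 uM, again a limit and not a number. For the compounds shown here, no step between compound 4 and compound 1, compound 2 or compound 3 can be read, because all four share one limit: the limit of > 10 uM in this assay, at which 4 of the 4 values shown sit. The compounds shown leave open how these four groups on the amide-type nitrogen would rank in this assay.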